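Swapping the sulfur-linked heteroaryl for an ethylpiperazine

The compounds below may be only part of what the source reports. "The series", "measured", "known", "first", "only" and "open" are said of these compounds alone.

Measured compounds:
compound 1 `Cn1nnnc1SCC(=O)Nc1ccc(-c2nc(-c3ccccc3)c(-c3ccccc3)n2C)cc1` 55.9%
compound 2 `Cn1ccnc1SCC(=O)Nc1ccc(-c2nc(-c3ccccc3)c(-c3ccccc3)n2C)cc1` 27.2%

In a functional assay on MCF7 cells (Homo sapiens) for cytotoxicity, read by MTT assay, with a stated time of 24 h, tested at 6.4 ug/mL (on this read-out higher numbers stand for a stronger effect at the one concentration tested and lower numbers for a weaker effect), compound 1 gives 55.9% and compound 2 gives 27.2%. Going by the values given here, the only measured step, a number 28.7 percentage points lower from compound 1 to compound 2 (beyond the scatter), concerns an exchange of one heteroaryl ring for another on the sulfur, and compound 2 stands lowest of the two numbers. Compound 3 `CCN1CCN(CC(=O)Nc2ccc(-c3nc(-c4ccccc4)c(-c4ccccc4)n3C)cc2)CC1` differs from compound 2 in another way: 4-ethylpiperazin-1-yl in place of (1-methyl-1H-imidazol-2-yl)sulfanyl on a saturated chain carbon bound to a carbonyl carbon. Among the compounds with values here, no measured step touches this kind of change, since the sulfur itself and the whole aromatic ring leave and a saturated ring with an ethyl group enters. Within the data shown here, the one measured step therefore only shows that this part of the molecule matters for the read-out, not in which direction this new change will move it. For compound 3 a step of a number 7.8 percentage points higher from compound 2 to compound 3 (within the scatter) is expected, with wide uncertainty, giving an estimated 35% between 10% and 65%.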

Compound 3, a percentage reported as activity, at one concentration (the size of the read-out at that concentration, not a potency): 16.4%
Compound 3: middle estimate off by 18.6 percentage points, on the high side; low and high end bracket the measured number.
By their numbers in this assay, from the lowest: compound 3; then compound 2; then compound 1.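

In this assay, placing 4-ethylpiperazin-1-yl on the saturated chain carbon bound to a carbonyl carbon gives a number 10.8 percentage points lower from compound 2 to compound 3 (beyond the scatter), and measured against the (1-methyl-1H-tetrazol-5-yl)sulfanyl group it gives a number 39.5 percentage points lower from compound 1 to compound 3 (beyond the scatter). The direction that the earlier step could not show is now visible: among these three compounds, both sulfur-linked aromatic groups give higher numbers than this saturated ring, and the largest step separates it from the tetrazole compound. Nothing available here explains this drop.

Because the sulfur and the aromatic ring leave together, their separate contributions remain unresolved. A morpholin-4-yl group would test another saturated ring, while a 1-methyl-1H-tetrazol-5-yl group joined through an amino link instead of sulfur would show whether the sulfur itself matters.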